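Working notes: from compound 2 to compound 3

The source may report more compounds than this note shows. Statements on the series, on what has been measured and on what is new or still open speak of the compounds shown alone.

Values in a functional assay on HT-1080 cells (Homo sapiens) for cytotoxicity, read by MTT assay, with a stated time of 72 h (on this read-out higher numbers stand for weaker inhibition and lower numbers for stronger inhibition), so far
- compound 1 `COc1cccc(/C=C2\CCC/C(=C\c3ccc(Cl)cc3)C2=O)c1OC` gives 11100 nM
- compound 2 `COc1ccccc1/C=C1\CCC/C(=C\c2ccc(OC)c(OC)c2)C1=O` gives 8100 nM

Compound 2 stands within the scatter of compound 1, so the two values are not separated. Compound 3 `COc1ccc(/C=C2\CCC/C(=C\c3ccc(Cl)c(Cl)c3)C2=O)cc1OC` carries 3,4-dichlorophenyl in place of 2-methoxyphenyl on a double-bonded chain carbon bound to a double-bonded ring carbon. For the measured compounds named here, no measured pair isolates a single change, so the expectation in this assay rests only on compound 1 (11100 nM) and compound 2 (8100 nM) lying within the scatter. A step within the scatter is expected (a 1.2-fold lower number from compound 2 to compound 3 (0.06 log units; within the scatter)). For compound 3 the estimated value is 7000 nM with an expected range from 2800 nM to 16000 nM as the working figure.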

Compound 3, half-maximal inhibitory concentration: 3100 nM
For compound 3 the middle estimate is 2.3-fold (0.35 log units) above the measured one; low and high end bracket the measured number.
By their numbers in this assay, from the lowest: compound 3; then compounds 2 and 1 (each within the scatter of the next).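

In this assay, for the compounds shown here, putting 3,4-dichlorophenyl in place of 2-methoxyphenyl on a double-bonded chain carbon bound to a double-bonded ring carbon gives a 2.6-fold lower number from compound 2 to compound 3 (0.42 log units; beyond the scatter) and is the first step beyond the scatter, though a modest one. The aryl group at this position can therefore shift the number, which compound 1 and compound 2 could not show. From the compounds shown here alone, whether the shift follows from gaining the two chlorines or losing the methoxy stays open, as does how a dimethylamine or a carboxylic acid on that phenyl would read. Nothing at hand accounts for the step.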